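This account rests on a few compounds, and the source may have more. Where it says the series, first, only, none or still open, it means among the compounds named here.

Measured so far in a functional assay on HT-29 cells (Homo sapiens) for cytotoxicity, read by MTT assay, with a stated time of 48 h; a higher number here means a weaker inhibitor, a lower number a stronger inhibitor:
- Compound 1 `CS(=O)(=O)c1ccc(Cc2nnc3n2N=C(c2cc(Cl)sc2S(N)(=O)=O)CS3)cc1`: > 100000 nM, a limit and not a number
- Compound 2 `CS(=O)(=O)c1ccc(Cc2nnc3n2N=C(c2ccc(Cl)cc2Cl)CS3)cc1`: > 100000 nM, a limit and not a number

Compound 2 therefore has only a limit to its name. Compound 3 `Cc1ccc(C2=Nn3c(Cc4ccc(S(C)(=O)=O)cc4)nnc3SC2)cc1` differs from it in one place, 4-methylphenyl in place of 2,4-dichlorophenyl on a carbon with a double bond to nitrogen. Among the measured compounds shown here, the only measured step, a step that the two limits leave unreadable from compound 1 to compound 2, changed that same carbon's group, but it gives no size to carry over. The evidence is the limit of > 100000 nM in this assay, at which 2 of the 2 values shown sit. No step beyond the scatter is therefore expected in this assay. The expected step is a number no higher from compound 2 to compound 3 (the limit leaves the size open). For compound 3 the estimate is 100000 nM, with a range of 30000 nM to 300000 nM.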

Compound 3, half-maximal inhibitory concentration: > 100000 nM
Compound 3 ended at the assay's limit; the forecaster's own chance of this, stated with the estimate: 75%; the middle value sits exactly at the limit.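

Compound 1, compound 2 and compound 3 all stop at a limit rather than a number, so no step among them can be read: the limit of > 100000 nM in this assay, at which 3 of the 3 values shown sit.

The compounds shown leave open whether any group on the carbon with a double bond to nitrogen would give a measurable value.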